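The source may report more compounds than this note shows. Statements on the series, on what has been measured and on what is new or still open speak of the compounds shown alone.

Among the measured compounds shown here, in a functional assay on B16-F10 cells (Mus musculus) for inhibition, read by MTT assay, with a stated time of 72 h (on this read-out lower numbers stand for stronger inhibition and higher numbers for weaker inhibition), compound 3 `COc1ccc(Nc2nc(SCc3cn(CC(=O)NC(=O)Nc4ccccn4)nn3)nc(-c3ccc(C(C)C)cc3)c2C#N)cc1` gives 360 nM, the lowest of the three numbers measured so far. Compound 2 `CC(C)c1ccc(-c2nc(SCc3cn(CC(=O)NC(=O)Nc4ccccn4)nn3)nc(Nc3ccc(Cl)cc3)c2C#N)cc1` gives 860 nM, and compound 1 `CC(C)c1ccc(-c2nc(SCc3cn(CC(=O)NC(=O)Nc4ccccn4)nn3)nc(Nc3ccccc3Cl)c2C#N)cc1` gives 6790 nM. Both measured changes on the nitrogen on the aromatic ring move the same way: a 19-fold lower number from compound 1 to compound 3 (1.28 log units; beyond the scatter), while a 2.4-fold lower number from compound 2 to compound 3 (0.38 log units; beyond the scatter) is the smaller exchange of one substituent for another at the same position. Compound 4 `COc1ccccc1Nc1nc(SCc2cn(CC(=O)NC(=O)Nc3ccccn3)nn2)nc(-c2ccc(C(C)C)cc2)c1C#N` has not yet been measured and differs from compound 3 in one place: 2-methoxyphenyl in place of 4-methoxyphenyl on a nitrogen on an aromatic ring. The step that bears most directly on this is a 7.9-fold lower number from compound 1 to compound 2 (0.90 log units; beyond the scatter), which is the same relocation of a substituent run in the opposite direction. Compound 4 is therefore expected to show a higher number than compound 3, with the expected step being a 6.1-fold higher number from compound 3 to compound 4 (0.79 log units; beyond the scatter), of a size comparable to that earlier relocation rather than within the scatter. Compound 4 is estimated at 2200 nM, with a range from 700 nM to 7000 nM.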

Compound 4, half-maximal inhibitory concentration: 34600 nM
The estimate for compound 4 lay 16-fold (1.20 log units) below the measured number; measured number outside the range, above it.
By their numbers in this assay, from the lowest: compound 3; then compound 2; then compound 1; then compound 4.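

On the nitrogen on the aromatic ring, moving methoxy alone changes the number far more than the earlier chloro relocation did (a 96-fold higher number from compound 3 to compound 4 (1.98 log units; beyond the scatter)) in this assay. The exchange of 4-chlorophenyl for 2-methoxyphenyl is also large (a 40-fold higher number from compound 2 to compound 4 (1.60 log units; beyond the scatter)), and the compounds carrying 2-chlorophenyl and 2-methoxyphenyl now hold the two highest numbers of the four. Methoxy in place of chloro lowered the number with the 4-substituted pair but raises it with the 2-substituted pair (a 5.1-fold higher number from compound 1 to compound 4 (0.71 log units; beyond the scatter)), so this exchange has no single direction here: the same change on two cores in this assay, a 2.4-fold lower number (0.38 log units; beyond the scatter) from compound 2 to compound 3 and a 5.1-fold higher number (0.71 log units; beyond the scatter) from compound 1 to compound 4, 12-fold (1.09 log units) apart, beyond the scatter of two such steps.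

Where 3-methoxyphenyl or unsubstituted phenyl would fall on this nitrogen remains open, as does whether 2-fluorophenyl or 2-methylphenyl would track the two 2-substituted compounds. The compounds shown also leave open why the 2-substituted pair differs from the 4-substituted pair.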